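A few compounds are considered here, and "the series" means these few. Any claim that something is new, unique, unknown or untested is made for them only; others in the source may bear on it.

In an ADME assay on L1210/0 cells (Mus musculus) for cytotoxicity, with a stated time of 48 h (a lower number here means a stronger inhibitor, a higher number a weaker inhibitor), compound 1 `O=c1ccn(C[C@@H]2CCC[C@H]2CO)c(=O)[nH]1` reaches only the limit > 200000 nM. Compound 2 `O=c1ccn([C@@H]2CCC[C@H]2CO)c(=O)[nH]1` likewise gives only the limit > 200000 nM in this assay. Compound 3 `O=c1[nH]c(=O)n([C@H]2C[C@H](O)[C@@H](CO)O2)cc1C#CCCCO` gives the limit > 200000 nM in this assay, so no number, only a limit, is known for it. The whole picture is the limit of > 200000 nM in this assay, at which 3 of the 3 values shown sit. Compound 4 `CCCCC#Cc1cn([C@H]2C[C@H](O)[C@@H](CO)O2)c(=O)[nH]c1=O` differs from compound 3 by methyl in place of hydroxy on a saturated chain carbon, three bonds along the chain from a triple-bonded carbon. Among the compounds with values here, no measured step between two compounds of this set exists to guide an expectation, so the change is judged from compound 3 alone. The expected step of a number no higher from compound 3 to compound 4 (the limit leaves the size open) is none beyond the scatter, with compound 4 most likely reported at a limit as well. Compound 4 is estimated at 200000 nM, within 60000 nM to 400000 nM in this assay.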

Compound 4, half-maximal inhibitory concentration: > 200000 nM
Compound 4 ended at the assay's limit; the forecaster's own chance of this, stated with the estimate: 75%; the middle value lies on the limit itself.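

Within the data shown here, compound 3 and compound 4 both end at a limit, so no step between them can be read. The compounds shown leave open what any real value would be and which change would shift it, as they share one result: the limit of > 200000 nM in this assay, at which 4 of the 4 values shown sit.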